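The source may hold more compounds than are shown below. What is called first, only, known or untested is meant among the compounds shown, and "the series" means these compounds.

Three compounds have been measured in a functional assay on PANC-1 cells (Homo sapiens) for inhibition, read by MTT assay, with a stated time of 24 h; a lower number here means a stronger inhibitor, a higher number a weaker inhibitor:

Compound 1 `CC1(C)[C@H]2CC[C@]1(C)N(Cc1cn(-c3cccc(C#N)c3)nn1)C(=O)C2` gives 260 nM.
Compound 2 `CC1(C)[C@H]2CC[C@]1(C)N(Cc1cn(-c3ccccc3F)nn1)C(=O)C2` gives 150 nM.
Compound 3 `CC1(C)[C@H]2CC[C@]1(C)N(Cc1cn(-c3ccc(Br)cc3)nn1)C(=O)C2` gives 200 nM.

All three share the same core and differ only in the aromatic group attached to the aromatic nitrogen. Compound 2 sits at one end of these three numbers, yet neither neighbour is separated from it by more than the scatter: a 1.7-fold lower number from compound 1 to compound 2 (0.24 log units; within the scatter), and a 1.3-fold higher number from compound 2 to compound 3 (0.12 log units; within the scatter). The three measured compounds therefore behave alike within the precision of this assay.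

Compound 4 `CC1(C)[C@H]2CC[C@]1(C)N(Cc1cn(-c3ccc(Cl)cc3)nn1)C(=O)C2` is the next step from compound 2. The change is 4-chlorophenyl in place of 2-fluorophenyl on an aromatic nitrogen. The measured step that bears most closely on it is the one in which a 4-bromophenyl also replaced the 2-fluorophenyl, a 1.3-fold higher number from compound 2 to compound 3 (0.12 log units; within the scatter), a change within the scatter; the comparison a 1.3-fold lower number from compound 1 to compound 3 (0.11 log units; within the scatter) likewise stayed within the scatter. On this basis, the step from compound 2 to compound 4 is expected to be small, leaning if anything toward a slightly higher number: a 1.3-fold higher number from compound 2 to compound 4 (0.10 log units; within the scatter). Compound 4 is therefore estimated at 190 nM, with a likely range from 90 nM to 400 nM.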

Compound 4, half-maximal inhibitory concentration: 440 nM
Compound 4: middle estimate off by 2.3-fold (0.36 log units), on the low side; the measured number lies above the stated range.
By their numbers in this assay, from the lowest: compounds 2, 3, 1 and 4 (each within the scatter of the next, the first and the last beyond it).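

In this assay, among the compounds shown here, the aromatic group on the ring nitrogen is no longer a place where changes make no visible difference: a 2.9-fold higher number from compound 2 to compound 4 (0.47 log units; beyond the scatter) is a modest step, but unlike the earlier steps it lies beyond the scatter. The closest comparison shows that a single atom can count here, since with chloro in place of bromo there is a 2.2-fold higher number from compound 3 to compound 4 (0.34 log units; beyond the scatter) and the step is again beyond the scatter. Compound 4 still cannot be told apart from the nitrile-bearing compound, as a 1.7-fold higher number from compound 1 to compound 4 (0.23 log units; within the scatter) stays within the scatter.

The compounds shown leave open how an amine or a carboxylic acid would behave in the place of the chloro. No measurement given here accounts for the gap between the chloro and bromo compounds.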